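The compounds below may be only part of what the source reports. "The series", "measured", "known", "first", "only" and "open" are said of these compounds alone.

Compound 3 `COc1cccc(CNCCCNc2ccnc3cc(-c4ccccc4)ccc23)c1O` stands level with its two neighbours in a physicochemical assay for acid dissociation: compound 3 gives 9.47, compound 1 `COc1cccc(CNCCCNc2ccnc3cc(-c4ccc(F)cc4)ccc23)c1O` gives 9.47 and compound 2 `COc1cccc(CNCCCNc2ccnc3cc(Cc4ccc(C#N)cc4)ccc23)c1O` gives 9.47. The three numbers do not separate at the digits recorded. The step from compound 1 to compound 2 was flat (no change at the digits printed from compound 1 to compound 2 (within the scatter)), the step from compound 1 to compound 3 was flat (no change at the digits printed from compound 1 to compound 3 (within the scatter)), and the step from compound 2 to compound 3 was flat as well (no change at the digits printed from compound 2 to compound 3 (within the scatter)).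

Compound 4 `COc1ccccc1Oc1ccc2c(NCCCNCc3cccc(OC)c3O)ccnc2c1` has not yet been measured in this assay. It differs from compound 3 in one place: 2-methoxyphenoxy in place of phenyl on an aromatic carbon. All three recorded steps exchanged the group at this same aromatic carbon of the shared core, moving between 4-fluorophenyl, 4-cyanobenzyl and phenyl, and none of them shifted the value beyond the scatter. Those steps therefore bear directly on the present change, and the expectation for compound 4 is that the exchange for 2-methoxyphenoxy likewise produces no step beyond the scatter, that is no change at the digits printed from compound 3 to compound 4 (within the scatter) as the expected step from compound 3. On that basis compound 4 is estimated at 9.47 in this assay, with an expected range of 9.15 to 9.8.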

Compound 4, acid dissociation constant: 9.28
Compound 4: the middle estimate sits 0.19 log units above what was measured; measured number inside the range.
By their numbers in this assay, from the lowest: compounds 4, 1, 2 and 3 (each within the scatter of the next).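

In this assay, the flat picture at this aromatic carbon now extends to 2-methoxyphenoxy, which stays within the scatter of all three groups shown before it (a number 0.19 log units lower from compound 3 to compound 4 (within the scatter); a number 0.19 log units lower from compound 2 to compound 4 (within the scatter); a number 0.19 log units lower from compound 1 to compound 4 (within the scatter)). Compared with phenyl, the entering group carries 9 heavy atoms against 6, and 2 hydrogen-bond acceptors against 0, so neither of these counted differences is accompanied by a step beyond the scatter in this pair. No accompanying data speak to the origin of these readings.

All the steps shown are exchanges at this one aromatic carbon, and every group placed there has no net charge, so it remains open whether a carboxylic acid or a dimethylamine group at the same carbon would stay within the scatter in this assay. Also open, going by these compounds, is how this assay responds to a change elsewhere in the molecule, such as a longer chain in place of the linking chain or an ethoxy group in place of the methoxy group on the phenol ring.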